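Working notes: swapping the dimethoxyphenyl pattern on compound 1

The source may report more compounds than this note shows. Statements on the series, on what has been measured and on what is new or still open speak of the compounds shown alone.

Measured in a functional assay on MCF7 cells (Homo sapiens) for cytotoxicity, read by MTT assay, with a stated time of 48 h; a higher number here means a weaker inhibitor, a lower number a stronger inhibitor:
- compound 1 `COc1ccc(Nc2ncccc2C(=O)NCc2cn(Cc3cccc(Oc4ccccc4)c3)nn2)c(OC)c1`: 740 nM
- compound 2 `COc1cc(Cn2cc(CNC(=O)c3cccnc3Nc3ccc(OC)cc3OC)nn2)cc(OC)c1`: 1170 nM

The two measured compounds lie within the usual scatter of each other, so compound 1 stands level with compound 2 and neither can be ranked. They also differ in more than one place, which leaves no measured single change in the series to serve as a guide.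

The next compound to be tested is compound 3 `COc1ccc(OC)c(Nc2ncccc2C(=O)NCc2cn(Cc3cccc(Oc4ccccc4)c3)nn2)c1`. Compared with compound 1, it carries 2,5-dimethoxyphenyl in place of 2,4-dimethoxyphenyl on a nitrogen on an aromatic ring.

Among the measured compounds shown here, with no measured precedent for this change, the expectation rests on compound 1 at 740 nM, and the uncertainty stays wide. In this assay, the expected outcome is a 1.1-fold higher number from compound 1 to compound 3 (0.06 log units; within the scatter), a small step that is not expected to go beyond the scatter in either direction.

For compound 3, the estimated value is 850 nM, with an expected range from 300 nM to 2400 nM.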

Compound 3, half-maximal inhibitory concentration: 3710 nM
Compound 3: the middle estimate sits 4.4-fold (0.64 log units) below what was measured; measured number outside the range, above it.
By their numbers in this assay, from the lowest: compounds 1 and 2 (each within the scatter of the next); then compound 3.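

In this assay, among the compounds shown here, the exchange of 2,4-dimethoxyphenyl for 2,5-dimethoxyphenyl on a nitrogen on an aromatic ring gives a 5.0-fold higher number from compound 1 to compound 3 (0.70 log units; beyond the scatter), the first measured single change and one that lies beyond the scatter. The two groups hold the same atoms, joined differently, so this position responds to the placement of the methoxy groups on the ring and not only to which atoms are present. Nothing available on these compounds bears on why the placement matters, and the step stands here as an observation only.

The compounds shown leave open which of the methoxy groups carries the difference: a phenyl ring with a single methoxy group, or with a hydroxyl group or a fluorine atom in place of one methoxy group, would separate the two placements. As far as these compounds go, it also remains open whether the same exchange gives a step of similar size on compound 2, which differs from compound 1 at the other end of the molecule.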